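The source may report more compounds than this note shows. Statements on the series, on what has been measured and on what is new or still open speak of the compounds shown alone.

Measured so far in an assay on LtK cells with ATP-sensitive inward rectifier potassium channel 11 (Homo sapiens) as the target; on this read-out higher numbers stand for an effect only at larger amounts of compound and lower numbers for an effect already at smaller amounts:

compound 1 `CC(C)=CC(=O)Nc1c(C(O)(C(F)(F)F)C(F)(F)F)ccc2ccccc12`: 46 nM
compound 2 `O=C(Nc1c(C(O)(C(F)(F)F)C(F)(F)F)ccc2ccccc12)C1CC1`: 751 nM
compound 3 `O=C(CC1CCCC1)Nc1c(C(O)(C(F)(F)F)C(F)(F)F)ccc2ccccc12`: 81 nM

Compound 3 gives the second highest of the three numbers. Its nearest neighbour is compound 1, a 1.8-fold higher number from compound 1 to compound 3 (0.25 log units; within the scatter), so the two are not separated. Compound 2 is the outlier: a 9.3-fold lower number from compound 2 to compound 3 (0.97 log units; beyond the scatter), and a 16-fold higher number from compound 1 to compound 2 (1.21 log units; beyond the scatter). The only clear signal so far is that the cyclopropyl directly on the carbonyl carbon reads weaker than either of the two larger groups.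

Compound 4 `O=C(Nc1c(C(O)(C(F)(F)F)C(F)(F)F)ccc2ccccc12)c1ccccc1Cl` has not yet been measured. The change: 2-chlorophenyl in place of cyclopentylmethyl on a carbonyl carbon. Among the compounds with values here, no measured step covers an aromatic ring, or a chlorine, on this carbonyl carbon, so the expectation rests on size alone. Cyclopropyl, the smallest group, gave the weak number of compound 2; the larger groups of compound 1 and compound 3 were alike. A 2-chlorophenyl is of comparable bulk to cyclopentylmethyl, so in this assay compound 4 is expected to stay near compound 3, a 1.9-fold higher number from compound 3 to compound 4 (0.27 log units; within the scatter), with a lean toward a higher number given the untested aromatic ring. Estimate for compound 4: 150 nM, range 40 nM to 600 nM.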

Compound 4, half-maximal effective concentration: 2040 nM
For compound 4 the middle estimate is 14-fold (1.13 log units) below the measured one; measured number outside the range, above it.
By their numbers in this assay, from the lowest: compounds 1 and 3 (each within the scatter of the next); then compound 2; then compound 4.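

In this assay, group size alone does not order this position: 2-chlorophenyl in place of cyclopentylmethyl on the carbonyl carbon gives a large rise (a 25-fold higher number from compound 3 to compound 4 (1.40 log units; beyond the scatter)), although the two groups differ little in heavy-atom count. The 2-chlorophenyl group also reads worse than the much smaller cyclopropyl (a 2.7-fold higher number from compound 2 to compound 4 (0.43 log units; beyond the scatter)) and far worse than 2-methylprop-1-en-1-yl (a 44-fold higher number from compound 1 to compound 4 (1.65 log units; beyond the scatter)), so compound 4 goes against the earlier impression that only the smallest group reads weak. No measurement at hand accounts for this change.

From the compounds shown here alone, whether the higher number goes with the aromatic ring or with the chlorine stays open, and a plain phenyl on the same carbonyl carbon would separate the two. Also open, going by these compounds, is how a benzyl group or a longer alkyl chain would read at this position.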